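A few compounds are considered here, and "the series" means these few. Any claim that something is new, unique, unknown or untested is made for them only; others in the source may bear on it.

Measured compounds:
- Compound 1, `C=CS(=O)(=O)c1cc(C(F)(F)F)cc(C(F)(F)F)c1`, gives in an ADME assay for pharmacokinetics, read by LC-MS, in phosphate buffer, with a stated time of 72 h, at pH 7.4, tested at 250 uM (on this read-out higher numbers stand for a longer-lived compound and lower numbers for a shorter-lived compound), a value of < 0.017 h.
- Compound 2, `C#Cc1cc(C(F)(F)F)cc(C(F)(F)F)c1`, gives in this assay a value of 5.9 h.

The value of compound 1 is a limit of the assay, not a number (the limit of < 0.017 h in this assay, at which 1 of the 2 values shown sits). Between these two, the step of an at least 340-fold higher number from compound 1 to compound 2 (2.54 log units; beyond the scatter) is the only measured change, and it swaps the whole group on the aromatic carbon. Among the measured compounds shown here, compound 2 therefore holds the only true number in this assay; the other entry is a limit.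

Compound 3, `N#Cc1cc(C(F)(F)F)cc(C(F)(F)F)c1`, differs from compound 2 by cyano in place of ethynyl on an aromatic carbon. For the measured compounds named here, no measured step touches this exchange: the step from compound 1 to compound 2 replaced a different group altogether, so it gives only a loose sense of how widely values in this assay can move. With nothing pointing to a shorter life, compound 3 is expected to keep a value of the same order as compound 2 or somewhat longer, a step of a 2.5-fold higher number from compound 2 to compound 3 (0.41 log units; beyond the scatter). The estimate for compound 3 in this assay is 15 h, within 3 h to 72 h.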

Compound 3, half-life: 50 h
For compound 3 the middle estimate is 3.3-fold (0.52 log units) below the measured one; the measured number falls inside the stated range.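

In this assay, two groups that look alike on paper do not behave alike at this position: both ethynyl and cyano carry a triple bond outside the ring and have the same count of heavy atoms, yet the exchange gives an 8.5-fold higher number from compound 2 to compound 3 (0.93 log units; beyond the scatter). So the read-out responds not only to replacing the whole group, as the earlier step did, but also to a carbon giving way to a nitrogen within a group of the same shape on paper, and compound 3 is the longest-lived of the three. The wider comparison, an at least 2900-fold higher number from compound 1 to compound 3 (3.46 log units; beyond the scatter), rests on a limit and not on a number for compound 1: the limit of < 0.017 h in this assay, at which 1 of the 3 values shown sits.

On these data alone, what the nitrile contributes remains open, as a single exchange cannot show whether the longer half-life would carry over to other groups at this position, such as a carboxylic acid, an amide or a primary amine. As far as these compounds go, all three compounds also keep the two trifluoromethyl groups, so it remains unknown how the half-life would change if either were replaced, for example by a methyl group or a chlorine atom.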